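Anilide aryl swap in a dopamine receptor agonist series

The source may hold more compounds than are shown below. What is called first, only, known or untested is meant among the compounds shown, and "the series" means these compounds.

Three members of the series have numbers in a functional assay on HEK293 cells for agonist activity at D(4) dopamine receptor (Homo sapiens), read by FLIPR; a lower number here means a smaller maximal response, a higher number a larger maximal response. Compound 1 `Cc1cc(C)cc(NC(=O)CN2CCC(c3cccc[n+]3[O-])CC2)c1` gives 76%, the highest number of the three. Compound 3 `CCc1cccc(C)c1NC(=O)CN1CCC(c2ccccn2)CC1` gives 70%, which lies within the usual scatter of compound 1, so the two cannot be ordered. Compound 2 `Cc1cccc(NC(=O)CN2CCC(c3ccccc3F)CC2)c1` gives 57%, a gap to compound 1 that lies beyond the scatter; compound 2 differs from compound 1 in more than one place, so no single change can be read from it. For the measured compounds named here, no pair of measured compounds differs in one place only, so no step has been quantified.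

Compound 4 `Cc1ccc(Cl)cc1NC(=O)CN1CCC(c2cccc[n+]2[O-])CC1` has not been measured. It differs from compound 1 in one place: 5-chloro-2-methylphenyl in place of 3,5-dimethylphenyl on an amide-type nitrogen. The shared core of compound 1 is retained. Going by the values given here, compound 3 at 70% shows that another substitution pattern on the anilide keeps the maximal response in the same region, which is the only guide available. On that basis the expected step is small, at most a slight drop, estimated as a number 8 percentage points lower from compound 1 to compound 4 (within the scatter). Compound 4 is therefore expected to give about 68% in this assay, with a range from 54% to 82%.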

Compound 4, largest response reached (reported as efficacy), in percent of the reference or control that the assay uses: 58%
For compound 4 the middle estimate is 10 percentage points above the measured one; measured number inside the range.
By their numbers in this assay, from the lowest: compounds 2 and 4 (each within the scatter of the next); then compounds 3 and 1 (each within the scatter of the next).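

For the compounds shown here, replacing 3,5-dimethylphenyl with 5-chloro-2-methylphenyl on the amide-type nitrogen gives the first quantified step: in this assay the change gives a number 18 percentage points lower from compound 1 to compound 4 (beyond the scatter). With the shared core of compound 1 retained, this shows that the maximal response depends on the anilide aryl group, even though the two groups match in heavy-atom count, in having one six-membered aromatic ring of carbon only, in carrying no hydrogen-bond donors or acceptors, and in having no net charge. No supporting data accompany the result, so the step stands as an observation without an explanation.

The swap brings in the chlorine and alters the methyl pattern in a single change, so the compounds shown cannot separate the contribution of each. As far as these compounds go, it also remains open whether a methoxy or a nitrile in place of the chlorine would retain the response of compound 1 or follow compound 4, and whether the step would carry over to a core without the N-oxide.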